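The source may hold more compounds than are shown below. What is called first, only, known or untested is meant among the compounds shown, and "the series" means these compounds.

Measured compounds in this study:
Compound 1, `CNC(=O)c1cc(Oc2ccc3nc(Nc4cccc(C(F)(F)F)c4)ncc3c2)ccn1`, gives < 1 10^-6 cm/s in an ADME assay on Caco-2 cells (Homo sapiens) for permeability, in the apical to basolateral direction (a lower number here means that the compound crosses the layer more slowly, a higher number that the compound crosses the layer faster), a value that is a limit of the assay.
Compound 2, `CNC(=O)c1cc(Oc2ccc3nc(Nc4cccc(C(C)C)c4)ncc3c2)ccn1`, gives < 1 10^-6 cm/s in this assay, again a limit.
Compound 3, `CNC(=O)c1cc(Oc2ccc3nc(Nc4ccc(C(F)(F)F)cc4)ncc3c2)ccn1`, gives < 1 10^-6 cm/s in this assay, again a limit.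

Compound 1 and compound 2 differ by isopropyl in place of trifluoromethyl on an aromatic carbon, and the step that the two limits leave unreadable from compound 1 to compound 2 cannot be sized. The two cores differ by 4-(trifluoromethyl)phenyl in place of 3-(trifluoromethyl)phenyl on a nitrogen on an aromatic ring, giving a step that the two limits leave unreadable from compound 1 to compound 3. The pair of compound 2 and compound 3 gives a step that the two limits leave unreadable from compound 2 to compound 3. All of this rests on (the limit of < 1 10^-6 cm/s in this assay, at which 3 of the 3 values shown sit).

Compound 4, `CNC(=O)c1cc(Oc2ccc3nc(Nc4ccc(C(C)C)cc4)ncc3c2)ccn1`, has not yet been measured in this assay. It differs from compound 3 by isopropyl in place of trifluoromethyl on an aromatic carbon. This is the same kind of change as that from compound 1 to compound 2, though there the isopropyl stood "meta to a large group" and here it stands "para to a large group". The earlier step is unreadable, so the expected step that the limit leaves unreadable from compound 3 to compound 4 from compound 3 to compound 4 is estimated as small. Compound 4 is therefore expected to give about 0.7 10^-6 cm/s, between 0.2 10^-6 cm/s and 2 10^-6 cm/s, most likely again reported as a limit.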

Compound 4, apparent permeability in the Caco-2 assay: < 1 10^-6 cm/s
Compound 4 was reported as a limit; the forecaster's own chance of this, stated with the estimate: 75%; the middle value does not contradict the limit.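

In the Caco-2 assay no new step can be read from compound 4 to compound 1, compound 2 or compound 3: the limit of < 1 10^-6 cm/s in the Caco-2 assay, at which 4 of the 4 values shown sit. In a physicochemical assay for solubility, at pH 7 (a higher number here means a more soluble compound, a lower number a less soluble compound), compound 3 gives < 1000 nM, a limit of the assay. In the physicochemical assay compound 4 gives < 1000 nM, again a limit of the assay. In the physicochemical assay compound 3 and compound 4 likewise leave no readable step: the limit of < 1000 nM in the physicochemical assay, at which 2 of the 2 values shown sit. The compounds shown leave open how large any of these steps is, and whether isopropyl in place of trifluoromethyl changes either read-out at all.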